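Inverting a ring stereocentre in a spirocyclic kinase inhibitor series

A few compounds are considered here, and "the series" means these few. Any claim that something is new, unique, unknown or untested is made for them only; others in the source may bear on it.

Measured compounds:
compound 1, `CCOCCN(C[C@@H](O)CN1CCCC2(CCN(c3ncnc4ccccc34)C2)C1)S(=O)(=O)c1c(C)cccc1C`, 2400 nM
compound 2, `Cc1cccc(C)c1S(=O)(=O)N1CCC[C@H]1[C@@H](O)CN1CCC[C@@]2(CCN(c3ncnc(N)c3C3CC3)C2)C1`, 690 nM

Of the compounds shown here, two have been measured in an assay on LNCaP cells for inhibition of RAC-alpha serine/threonine-protein kinase (Homo sapiens); on this read-out higher numbers stand for weaker inhibition and lower numbers for stronger inhibition. Compound 1 gives 2400 nM, while compound 2 gives 690 nM, the lowest of the two numbers; the gap to compound 1 is beyond the usual scatter, so compound 2 stands as the stronger of the pair. Compound 3, `Cc1cccc(C)c1S(=O)(=O)N1CCC[C@@H]1[C@@H](O)CN1CCC[C@@]2(CCN(c3ncnc(N)c3C3CC3)C2)C1`, has not yet been measured. It differs from compound 2 in configuration only: the two compounds have the same atoms and bonds and differ only in configuration as drawn: 1 of 3 stereo elements differ; a stereocentre at a saturated ring carbon is drawn S in compound 2 and R in compound 3. No pair of measured compounds differing in one place is available, so the size of this step cannot be anchored in a shown comparison. Inversion of a single stereocentre commonly shifts the read-out either way, and a move toward weaker inhibition is expected to be the more likely outcome. Compound 3 is therefore estimated at 1500 nM, within 350 nM to 6000 nM, an expected step of a 2.2-fold higher number from compound 2 to compound 3 (0.34 log units; beyond the scatter).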

Compound 3, half-maximal inhibitory concentration: 2400 nM
Compound 3: middle estimate off by 1.6-fold (0.20 log units), on the low side; the measured number falls inside the stated range.
By their numbers in this assay, from the lowest: compound 2; then compounds 1 and 3 (each within the scatter of the next).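

Inverting the stereocentre at a saturated ring carbon from S to R gives the first reading of a single change in this assay: a 3.5-fold higher number from compound 2 to compound 3 (0.54 log units; beyond the scatter). This position therefore responds to configuration alone, and in this pair the S form gives the lower number and so the stronger inhibition. The gap can be assigned to this one stereocentre because no other structural change accompanies it: the fact that compounds 2 and 3 differ only in the configuration as drawn.

The compounds shown leave open whether the S form would keep its advantage if either of the other two stereo elements were inverted, or on the core of compound 1. They also leave open what a methyl group or a fluorine in place of the hydrogen on that ring carbon would do to the number in this assay.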